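Replacing an acid-bearing ring with naphthalene in an aorta assay

The compounds below may be only part of what the source reports. "The series", "measured", "known", "first", "only" and "open" are said of these compounds alone.

Measured so far:
- compound 1 `COc1cc(C(C)=O)ccc1OCCCN1CCC(C(c2cccc(F)c2)c2cccc(F)c2)CC1`: 3.16 nM
- compound 2 `COc1cc(C(=O)O)ccc1OCCCN1CCC(C(c2ccc(F)cc2)c2ccc(F)cc2)CC1`: 79.4 nM

In a functional assay (aorta) with Oryctolagus cuniculus as the target (a higher number here means weaker binding, a lower number tighter binding), compound 2 gives the higher of the two numbers, so it binds more weakly than compound 1, whose value is 3.16 nM. Compound 3 `Fc1ccc(C(c2ccc(F)cc2)C2CCN(CCCOc3ccc4ccccc4c3)CC2)cc1` is not yet measured; it differs from compound 2 by naphthalen-2-yl in place of 4-carboxy-2-methoxyphenyl on an oxygen on a saturated carbon. Within the data shown here, no measured pair isolates this change, so the expectation rests on the fact that compound 1, which carries no carboxylic acid, shows 3.16 nM. A step toward tighter binding is expected, roughly a 13-fold lower number from compound 2 to compound 3 (1.12 log units; beyond the scatter) in size. For compound 3 the expected value in this assay is 6 nM, with a likely range from 1.5 nM to 30 nM.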

Compound 3, dissociation constant: 7.94 nM
Beside the measured number, compound 3's estimate is 1.3-fold (0.12 log units) below it; the range from low to high includes it.
By their numbers in this assay, from the lowest: compound 1; then compound 3; then compound 2.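

In this assay, placing naphthalen-2-yl instead of 4-carboxy-2-methoxyphenyl on the oxygen gives a 10-fold lower number from compound 2 to compound 3 (1.00 log units; beyond the scatter). Among these compounds, this is the first pair that differs in one place only, and it shows that this position accepts a group made of carbon alone, with no hydrogen-bond donors or acceptors, and that binding tightens with it. Nothing available explains the change. On these data alone, the swap alters several features at once, so it remains open whether the carboxylic acid, the methoxy group or the second ring accounts for the step. A plain phenyl group, or a 2-methoxyphenyl group, on that oxygen would help separate them.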